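Chain-terminal carboxylic acid in place of hydroxy: compound 4

This account rests on a few compounds, and the source may have more. Where it says the series, first, only, none or still open, it means among the compounds named here.

Measured so far:
Compound 1 `CCC(CC)(c1ccc(OS(=O)(=O)c2ccc(C)cc2)c(C)c1)c1ccc(OCC(=O)C(C)(C)C)c(OCC(=O)C(C)(C)C)c1` gives 35%.
Compound 2 `CCC(CC)(c1ccc(OCCCO)c(C)c1)c1ccc(OCC(O)C(C)(C)C)c(OCC(O)C(C)(C)C)c1` gives 76%.
Compound 3 `CCC(CC)(c1ccc(OCCCC(=O)O)c(C)c1)c1ccc(OCC(O)C(C)(C)C)c(OCC(O)C(C)(C)C)c1` gives 14%.

In an assay on cells for binding affinity to vitamin D3 receptor (Homo sapiens), read by fluorescence, tested at 1 uM (on this read-out lower numbers stand for less inhibition and higher numbers for more inhibition at the one concentration tested (going by the name of the read-out)), compound 2 stands highest of the three numbers. Compound 1 sits lower by a margin beyond the usual scatter, and compound 3 lies lowest, furthest from compound 2. Within the data shown here, the one step that changes a single place is the one from compound 2 to compound 3: a number 62 percentage points lower from compound 2 to compound 3 (beyond the scatter). That step is large and downward.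

Compound 4 `CCC(CC)(c1ccc(OCCCCCC(=O)O)c(C)c1)c1ccc(OCC(O)C(C)(C)C)c(OCC(O)C(C)(C)C)c1` has not been measured. It differs from compound 2 as follows: 2-carboxyethyl in place of hydroxy on a saturated chain carbon, three bonds along the chain from an oxygen on an aromatic ring. The change in compound 4 is of the same kind as in compound 3, the group on the saturated chain carbon three bonds from the aromatic oxygen ending in a carboxylic acid, here carried on a 2-carboxyethyl instead of directly on the chain. Among the measured compounds shown here, only the step from compound 2 to compound 3 bears on this, and it was large. A downward step of similar size is therefore expected for compound 4, a number 54 percentage points lower from compound 2 to compound 4 (beyond the scatter), while the longer chain leaves the exact size uncertain. Compound 4 is estimated at 22% in this assay, with a range from 5% to 50%.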

Compound 4, a percentage reported as inhibition, at one concentration (the size of the read-out at that concentration, not a potency): "not active" (no number reported)
For compound 4 the study gives words and no number; the estimate stays without a comparison.
By their numbers in this assay, from the lowest: compound 3; then compound 1; then compound 2.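

Among these compounds, compound 4 is reported only as "not active" in this assay, without a number, so no step from compound 2 or compound 3 to compound 4 can be read. No measurement shown bears on this result. The compounds shown leave open whether compound 4 falls under compound 3 at 14%, and how chain length affects the read-out.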